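From furan-3-yl to cyano on a shared core

The compounds below may be only part of what the source reports. "The series", "measured", "known", "first", "only" and "open" are said of these compounds alone.

Two compounds have been measured so far:
- compound 1 `Cc1cc(-c2ccc(C=O)cc2)cn2c(CSCCc3ccccc3)cnc12` gives 9.4 ug/mL
- compound 2 `Cc1cc(-c2ccoc2)c2ncc(CSCCc3ccccc3)n2c1` gives 64 ug/mL

Both numbers come from an ADME assay on HEL cells (Homo sapiens) for cytotoxicity, with a stated time of 3 days (a lower number here means that less compound is tolerated, a higher number that more compound is tolerated), and compound 2 stands highest of the two. Compound 1 lies lower by a gap beyond the usual scatter, so more of compound 2 is tolerated. These two compounds differ in more than one place, and their gap cannot be read as the effect of any single change.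

Compound 3 `Cc1cc(C#N)c2ncc(CSCCc3ccccc3)n2c1` has not yet been measured in this assay and matches compound 2 except at one place. Going by the values given here, it carries cyano in place of furan-3-yl on an aromatic carbon and no measured pair shows what such a swap does. The expectation therefore rests on compound 2 alone, at 64 ug/mL and nothing measured argues for a shift in either direction. The expected step is a 1.1-fold lower number from compound 2 to compound 3 (0.03 log units; within the scatter) and it is estimated to stay within the scatter. In this assay the estimate for compound 3 is an expected 60 ug/mL (range from 20 ug/mL to 100 ug/mL).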

Compound 3, half-maximal cytotoxic concentration: > 100 ug/mL
Compound 3 gave a limit, no number; the forecaster's own chance of this, stated with the estimate: 35%; at least 1.6-fold (0.22 log units) between middle value and limit.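

Going by these compounds alone, on the aromatic carbon of the shared core where compound 2 carries furan-3-yl, the swap to cyano is the first change that can be read on its own, and in this assay it gives an at least 1.5-fold higher number from compound 2 to compound 3 (0.19 log units; that floor lies within the scatter). Compound 3 gives > 100 ug/mL in this assay, and this is a limit of the assay, not a number. The ring of furan-3-yl can therefore leave this position, with cyano in its place, with no fall in the amount tolerated, but the printed step is only a floor and the true size of the change remains unread: the limit of > 100 ug/mL in this assay, at which 1 of the 3 values shown sits.

On these data alone, this single pair cannot separate the loss of the furan-3-yl ring from the arrival of the nitrile, so it remains open how a phenyl ring, a methyl group or an amine on the same carbon would read in this assay. Within the data shown here, it is also open whether cyano would give a similar step at another position on the shared core or alongside a chain other than the one these compounds share.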